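The source may hold more compounds than are shown below. What is called first, only, known or untested is meant among the compounds shown, and "the series" means these compounds.

Compound 1 `O=C(NCc1ccc(NC(=O)c2cc(Cl)ccc2N2CCCC2)cc1)OCc1cccnc1` was tested in a functional assay on BGC-823 cells (Homo sapiens) for inhibition, read by MTT assay, with a stated time of 72 h; a lower number here means a stronger inhibitor, a higher number a weaker inhibitor. In that test compound 1 gives > 100000 nM, which is a limit of the assay and not a number. A second member of the same series, compound 2 `O=C(NCc1ccc(NC(=O)c2cccc(F)c2N2CCCC2)cc1)OCc1cccnc1`, was measured as well. In this assay compound 2 gives > 100000 nM, again a limit rather than a number. Within the data shown here, compound 1 therefore stands at the limit of > 100000 nM in this assay, at which 2 of the 2 values shown sit, and the two values show only that both compounds sit at that same limit; no numerical gap between them can be stated.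

Compound 3 `O=C(NCc1ccc(NC(=O)c2cc(Br)ccc2N2CCCC2)cc1)OCc1cccnc1` has not yet been measured. It differs from compound 1 in one place: bromo in place of chloro on an aromatic carbon. Among the measured compounds shown here, no step between two measured compounds exists in this set, so the size of the change can only be expected, not read off. Compound 1 sits at a limit, and for compound 3 a limit is the likeliest outcome, with no shift in this assay beyond the usual scatter. The step that the limit leaves unreadable from compound 1 to compound 3 is expected to be small. Compound 3 is estimated at 150000 nM, with a range from 60000 nM to 400000 nM.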

Compound 3, half-maximal inhibitory concentration: > 100000 nM
Compound 3: a limit, no number; the forecaster's own chance of this, stated with the estimate: 85%; the middle value does not contradict the limit.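

Compound 1 and compound 3 both sit at a limit in this assay, not at a number, so the size of the step from chloro to bromo cannot be read. The whole set stands there: the limit of > 100000 nM in this assay, at which 3 of the 3 values shown sit. The compounds shown leave open how strongly, if at all, any of them inhibits these cells.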